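A few compounds are considered here, and "the series" means these few. Any claim that something is new, unique, unknown or untested is made for them only; others in the source may bear on it.

Working notes on the series. In a functional assay on A549 cells (Homo sapiens) for inhibition, read by MTT assay, with a stated time of 48 h (on this read-out higher numbers stand for weaker inhibition and lower numbers for stronger inhibition), compound 1 (`Cc1ccc(-c2nc3ccccn3c2Sc2ccccc2)cc1`) gives 94300 nM and compound 2 (`c1ccc(Sc2c(-c3cccs3)nc3ccccn23)cc1`) gives 16900 nM, so compound 2 holds the lower of the two numbers and the stronger inhibition so far. The next structure is compound 3 (`Clc1ccc(-c2nc3ccccn3c2Sc2ccccc2)cc1`), with 4-chlorophenyl in place of thiophen-2-yl on an aromatic carbon. Going by the values given here, only one measured step bears on this change: a 5.6-fold lower number from compound 1 to compound 2 (0.75 log units; beyond the scatter). That step is modest but beyond the scatter, and it came with thiophen-2-yl in place of 4-methylphenyl. Compound 3 returns to a substituted phenyl, so a step of similar or somewhat smaller size is expected in the opposite direction in this assay, towards a higher number. Among the compounds with values here, one step is thin support, and no other 4-chlorophenyl compound has been measured. The expected step is a 3.6-fold higher number from compound 2 to compound 3 (0.55 log units; beyond the scatter). The estimated value for compound 3 is 60000 nM, with an expected range of 22000 nM to 150000 nM.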

Compound 3, half-maximal inhibitory concentration: 22000 nM
Compound 3: the middle estimate sits 2.7-fold (0.44 log units) above what was measured; measured number inside the range.
By their numbers in this assay, from the lowest: compounds 2 and 3 (each within the scatter of the next); then compound 1.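

Working notes, continued. In this assay, 4-chlorophenyl and thiophen-2-yl on this aromatic carbon cannot be told apart (a 1.3-fold higher number from compound 2 to compound 3 (0.11 log units; within the scatter)), so a substituted phenyl here does not by itself go with the higher number of compound 1. Chloro in place of methyl on the phenyl ring gives a modest step (a 4.3-fold lower number from compound 1 to compound 3 (0.63 log units; beyond the scatter)), which shows that the substituent on that ring, and not only the ring type, moves the number at this position. No measurement at hand gives a reason for either step.

The compounds shown leave open whether fluoro, methoxy or trifluoromethyl on the phenyl ring would fall with compound 1 or with compounds 2 and 3. Also open, on these data alone, is how an amine or a carboxylic acid on the phenyl ring would read, and how the number responds to changes in the phenylsulfanyl group, which all three compounds share.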